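Permeability notes: trifluoromethoxy for bromo on the shared core

The source may report more compounds than this note shows. Statements on the series, on what has been measured and on what is new or still open speak of the compounds shown alone.

Compound 1 `CNC(=O)c1cc(Oc2ccc3nc(Nc4cccc(OC(F)(F)F)c4)ncc3c2)ccn1` and compound 2 `CNC(=O)c1cc(Oc2ccc3nc(Nc4ccc(Br)cc4)ncc3c2)ccn1` share one core. In an ADME assay on Caco-2 cells (Homo sapiens) for permeability, in the apical to basolateral direction (on this read-out higher numbers stand for higher permeability and lower numbers for lower permeability), compound 1 sits at the assay limit < 1 10^-6 cm/s. In this assay compound 2 likewise sits at the assay limit < 1 10^-6 cm/s. The step that the two limits leave unreadable from compound 1 to compound 2 is the only measured one bearing on the next change, and its size cannot be read because of the limit of < 1 10^-6 cm/s in this assay, at which 2 of the 2 values shown sit. Compound 3 `CNC(=O)c1cc(Oc2ccc3nc(Nc4ccc(OC(F)(F)F)cc4)ncc3c2)ccn1` differs from compound 2 by trifluoromethoxy in place of bromo on an aromatic carbon. The step that the limit leaves unreadable from compound 2 to compound 3 is expected to stay within the scatter, most likely again as a limit. Compound 3 is expected at 0.7 10^-6 cm/s, between 0.3 10^-6 cm/s and 2 10^-6 cm/s.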

Compound 3, apparent permeability: < 1 10^-6 cm/s
Compound 3 ended at the assay's limit; the forecaster's own chance of this, stated with the estimate: 75%; the middle value is on the limit's open side.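

The steps among compound 1, compound 2 and compound 3 cannot be read: the limit of < 1 10^-6 cm/s in this assay, at which 3 of the 3 values shown sit. The compounds shown leave open whether these changes on the shared core move the read-out in this assay at all, and by how much.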